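Adding methoxy to compound 2

This account rests on a few compounds, and the source may have more. Where it says the series, first, only, none or still open, it means among the compounds named here.

compound 1 `C=CCc1cc(-c2cccc([N+](=O)[O-])c2)ccc1O` gives > 100000 nM as a limit
compound 2 `C=CCc1cc(-c2ccccc2)ccc1O` gives > 100000 nM as a limit

Both compounds were tested in a functional assay on HepG2 cells (Homo sapiens) for antiproliferative activity, read by MTT assay, with a stated time of 24 h (a lower number here means a stronger inhibitor, a higher number a weaker inhibitor), and both entries are limits, not numbers. Compound 2 stands at > 100000 nM as a limit, so no number is available for it. The whole picture so far is the limit of > 100000 nM in this assay, at which 2 of the 2 values shown sit, and nothing more.

Compound 3 `C=CCc1cc(-c2ccc(OC)cc2)ccc1O` carries one change from compound 2, counted in methoxy in place of hydrogen on an aromatic carbon and described here: methoxy in place of hydrogen on an aromatic carbon, para to a large group.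

For the measured compounds named here, the only measured step that bears on this is a step that the two limits leave unreadable from compound 1 to compound 2 where hydrogen stands in place of nitro on an aromatic carbon. It has no readable size and involves a different group, so it offers no number to carry over. With compound 2 at > 100000 nM as its limit, no clear step in either direction is expected in this assay for this change. The estimated step is a step that the limit leaves unreadable from compound 2 to compound 3 and it is only an expectation. For compound 3 the expected value is 150000 nM with an estimated range from 50000 nM to 400000 nM and a report as a limit is the likeliest outcome.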

Compound 3, half-maximal inhibitory concentration: > 100000 nM
Compound 3: a limit, no number; the forecaster's own chance of this, stated with the estimate: 80%; the middle value is on the limit's open side.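

In this assay compound 3 gives > 100000 nM, which is a limit and not a number. For the compounds shown here, compound 2 also gives only a limit, so no step between compound 2 and compound 3 can be read. Compound 1, compound 2 and compound 3 leave open how any change to the shared core affects the potency in this assay.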